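Removing the Bromo Group: What to Expect for Compound 4

The source may report more compounds than this note shows. Statements on the series, on what has been measured and on what is new or still open speak of the compounds shown alone.

Three compounds have been measured in a functional assay for inhibition, with Rattus norvegicus as the target; on this read-out lower numbers stand for stronger inhibition and higher numbers for weaker inhibition:

Compound 1 `CCC(C)(C)/N=c1\c(O)c(O)\c1=N/Cc1c(C)cc(C)cc1C` gives 310 nM.
Compound 2 `CCC(C)(C)/N=c1\c(O)c(O)\c1=N/Cc1c(C)cccc1Cl` gives 4400 nM.
Compound 3 `CCC(C)(C)/N=c1\c(O)c(O)\c1=N/Cc1c(C)cc(Br)cc1C` gives 1200 nM.

Compound 3 stands second highest of these three numbers in this assay. Its nearest neighbour is compound 2, whose number is higher, while compound 1 has the lowest number of the set; both gaps are beyond the scatter. Going by the values given here, the one single-point step among the measured compounds runs between compound 1 and compound 3, where the number rose by a 3.9-fold higher number from compound 1 to compound 3 (0.59 log units; beyond the scatter) when bromo replaced methyl on an aromatic carbon.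

Compound 4 `CCC(C)(C)/N=c1\c(O)c(O)\c1=N/Cc1c(C)cccc1C` is compound 3 with the bromo group taken away: hydrogen in place of bromo on an aromatic carbon. Among the compounds with values here, no measured compound carries hydrogen at that place, so the step has no direct precedent. Within the data shown here, the methyl-to-bromo step from compound 1 to compound 3 is the only guide, and it suggests that the group on this carbon matters for this assay. A hydrogen there is expected to give a number between those of compound 1 and compound 3, so compound 4 is estimated at 600 nM (range 250 nM to 1500 nM), a step of a 2.0-fold lower number from compound 3 to compound 4 (0.30 log units; within the scatter) from compound 3, expected to be a modest lowering.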

Compound 4, half-maximal inhibitory concentration: 830 nM
Estimate against measurement, compound 4: 1.4-fold (0.14 log units) below; the range from low to high includes it.
By their numbers in this assay, from the lowest: compound 1; then compounds 4 and 3 (each within the scatter of the next); then compound 2.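

In this assay, the carbon para to a large group can now be compared across three groups, and hydrogen and bromo at that carbon cannot be told apart, with a 1.4-fold lower number from compound 3 to compound 4 (0.16 log units; within the scatter) as the step between them. Methyl is the group that stands out here: putting hydrogen in its place gives a 2.7-fold higher number from compound 1 to compound 4 (0.43 log units; beyond the scatter) as a step, and putting bromo in its place gives a 3.9-fold higher number from compound 1 to compound 3 (0.59 log units; beyond the scatter) as a step, so the earlier change is no longer specific to bromo. Another place on the ring also counts, as methyl in place of chloro gives a 5.3-fold lower number from compound 2 to compound 4 (0.72 log units; beyond the scatter) for one of the two methyl groups of compound 4, a step that can be read clearly beyond the usual spread of repeats.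

Still open, as far as these compounds go, is whether a methoxy group, an amine or a longer chain such as propyl at the para carbon would behave like methyl or like hydrogen and bromo. Nothing available explains why these groups give these differences.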